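A Dimethylamino Group Added to Compound 1

The source may report more compounds than this note shows. Statements on the series, on what has been measured and on what is new or still open speak of the compounds shown alone.

In a functional assay on the whole organism (strain Sprague-Dawley) for inhibition, with Rattus norvegicus as the target, with a stated time of 10 min (a higher number here means that more compound is needed for the effect, a lower number that less compound is needed), compound 1 `CCOc1ccccc1-c1ncc(C(=O)O)c(=O)[nH]1` gives 0.5 mg/kg, and compound 2 `CCC(C)Oc1ccccc1-c1ncc(C(=O)O)c(=O)[nH]1` gives 0.5 mg/kg, so the two stand level. Among the measured compounds shown here, the only measured step is no change at the digits printed from compound 1 to compound 2 (within the scatter). In that step, ethyl takes the place of hydrogen on a saturated chain carbon bound to the oxygen, so the change lies in the chain and not on the aromatic ring.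

The next compound is compound 3 `CCOc1ccc(N(C)C)cc1-c1ncc(C(=O)O)c(=O)[nH]1`, which differs from compound 1 by dimethylamino in place of hydrogen on an aromatic carbon. Here, dimethylamino stands in place of hydrogen on an aromatic carbon, para to an ethoxy group. For the measured compounds named here, no measured compound carries a group at this carbon, so the data give no direct guide to the size or direction of this change. Going by the values given here, the measured step bears on it only indirectly, as the one structural change seen so far, and it gives no reason to expect a large shift. The expected result is a 1.6-fold higher number from compound 1 to compound 3 (0.20 log units; within the scatter), estimated to stay within the usual scatter, with a slight lean towards more compound being needed. For compound 3 the estimated dose is 0.8 mg/kg, with an expected range from 0.2 mg/kg to 3 mg/kg.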

Compound 3, dose for 50% inhibition: 0.3 mg/kg
Compound 3: middle estimate off by 2.7-fold (0.43 log units), on the high side; low and high end bracket the measured number.
By their numbers in this assay, from the lowest: compounds 3, 1 and 2 (each within the scatter of the next).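

In this assay, among the compounds shown here, the step of a 1.7-fold lower number from compound 1 to compound 3 (0.22 log units; within the scatter) gives the first reading at the aromatic carbon para to an ethoxy group, where dimethylamino stands in place of hydrogen. The earlier step lay in the chain on the oxygen and said nothing about the ring, whereas this one shows that a group of 3 heavy atoms at this carbon leaves the dose within the scatter of compound 1. Nothing at hand gives a measured reason for this result, and no cause can be assigned to it.

On these data alone, it remains open whether other groups at this carbon, such as a primary amine, a methoxy group or a chlorine atom, would also stay within the scatter of compound 1, and whether dimethylamino would do the same on another carbon of this ring. As far as these compounds go, it is also open whether dimethylamino at this carbon would give a similar result when combined with the longer chain on the oxygen of compound 2, or with a longer chain still.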